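Working notes on the step from compound 2 to compound 3

A few compounds are considered here, and "the series" means these few. Any claim that something is new, unique, unknown or untested is made for them only; others in the source may bear on it.

Among the compounds with values here, compound 2 `CCCCN(c1nc2c(CO)cccc2o1)[C@H](C)c1ccc(-c2ccccc2-c2nnn[nH]2)cc1` stands highest of the two numbers so far in an ADME assay on the whole organism (plasma, Macaca fascicularis) for protein binding, read by LC-MS, using equilibrium dialysis and cassette dosing, with a stated time of 24 h, at a dose of 1 mg/kg by the oral route (a lower number here means a smaller unbound share, a higher number a larger unbound share of the compound), with 0.00112; compound 1 `CCCCN(c1nc2ccccc2o1)[C@H](C)c1ccc(-c2ccccc2-c2nnn[nH]2)cc1` gives 0.000713, and the step of a 1.6-fold higher number from compound 1 to compound 2 (0.20 log units; within the scatter) is within the scatter, so no order between these two can be claimed. Compound 3 `CCCCN(c1nc2c(-c3ccccn3)cccc2o1)[C@H](C)c1ccc(-c2ccccc2-c2nnn[nH]2)cc1` differs from compound 2 by pyridin-2-yl in place of hydroxymethyl on an aromatic carbon. Within the data shown here, the only measured step, hydrogen to hydroxymethyl on the same aromatic carbon, bears on this change, but it carried no shift beyond the scatter, and no step in the set removes a hydroxymethyl or brings in an aromatic ring. The expected change in this assay is therefore none beyond the scatter, with a slight lean towards a lower unbound fraction that the data cannot firmly support. Compound 3 is estimated at 0.0008, range 0.0003 to 0.002, which means an expected step of a 1.4-fold lower number from compound 2 to compound 3 (0.15 log units; within the scatter).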

Compound 3, unbound fraction: 0.00129
Compound 3: middle estimate off by 1.6-fold (0.21 log units), on the low side; the measured number falls inside the stated range.
By their numbers in this assay, from the lowest: compounds 1, 2 and 3 (each within the scatter of the next).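

In this assay, pyridin-2-yl on this aromatic carbon in place of hydroxymethyl gives a 1.2-fold higher number from compound 2 to compound 3 (0.06 log units; within the scatter) and the same group in place of hydrogen gives a 1.8-fold higher number from compound 1 to compound 3 (0.26 log units; within the scatter) so neither step leaves the scatter. The position has now carried hydrogen, hydroxymethyl and an aromatic six-membered ring, and exchanging the hydrogen-bond donor of hydroxymethyl for pyridin-2-yl, with its larger count of heavy atoms, brings no shift beyond the scatter in this series. Nothing at hand gives a reason for this result.

As far as these compounds go, whether a basic amine such as aminomethyl, a carboxylic acid or a longer alkyl chain on this carbon would move the number in this assay beyond the scatter remains open. Equally open, from the compounds shown here alone, is whether pyridin-2-yl would behave the same way on another aromatic carbon of the core.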